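A few compounds are considered here, and "the series" means these few. Any claim that something is new, unique, unknown or untested is made for them only; others in the source may bear on it.

Going by the values given here, in a functional assay on MOLT-4 cells (Homo sapiens) (a lower number here means a stronger inhibitor, a higher number a weaker inhibitor), compound 2 `Cc1ccc(-c2ncnc3c2ncn3C[C@@H]2C[C@H](CO)c3ccccc32)cc1` gives 1.4 ug/mL, the lower of the two numbers so far, and compound 1 `Nc1ncnc2c1ncn2C[C@@H]1C[C@H](CO)c2ccccc21` gives 24 ug/mL. Compound 3 `OC[C@H]1C[C@@H](Cn2cnc3c(NC4CC4)ncnc32)c2ccccc21` has cyclopropylamino in place of 4-methylphenyl on an aromatic carbon. Among the compounds with values here, one measured step bears on this change, the large 17-fold lower number from compound 1 to compound 2 (1.23 log units; beyond the scatter), with 4-methylphenyl in place of amino at that same carbon. Cyclopropylamino is not amino, so only part of that step is expected to reverse. The expected step is a 5.7-fold higher number from compound 2 to compound 3 (0.76 log units; beyond the scatter), towards a higher number in this assay. For compound 3 the estimate is 8 ug/mL, with an expected range of 2.5 ug/mL to 25 ug/mL.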

Compound 3, half-maximal inhibitory concentration: 24 ug/mL
Estimate against measurement, compound 3: 3.0-fold (0.48 log units) below, within the range that was stated.
By their numbers in this assay, from the lowest: compound 2; then compounds 1 and 3 (each within the scatter of the next).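

In this assay, replacing 4-methylphenyl with cyclopropylamino on this aromatic carbon gives up the whole gain over the amino compound (a 17-fold higher number from compound 2 to compound 3 (1.23 log units; beyond the scatter)). Cyclopropyl on the nitrogen makes no difference from the plain amino group (no change at the digits printed from compound 1 to compound 3 (within the scatter)), so among these three compounds only 4-methylphenyl gives the lower number. Nothing available explains this difference between the groups. Still open, going by these compounds, is whether unsubstituted phenyl or 4-methoxyphenyl would keep the lower number. Also open, on these data alone, is whether benzylamino or morpholine would match the amino compounds or go beyond them.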